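Bromo in place of methoxy on the aromatic ring

The compounds below may be only part of what the source reports. "The series", "measured", "known", "first", "only" and "open" are said of these compounds alone.

Two measured compounds share one core and differ in a single group on the outer ring. Compound 1 `O=C(NNc1nc2ccccc2nc1Cc1ccccc1)c1ccccc1` carries a hydrogen there, and in an assay for inhibition of Amine oxidase [flavin-containing] A (Bos taurus), read by fluorescence, with a stated time of 60 min (on this read-out higher numbers stand for weaker inhibition and lower numbers for stronger inhibition), compound 1 gives 78 nM. Compound 2 `COc1ccc(C(=O)NNc2nc3ccccc3nc2Cc2ccccc2)cc1` carries a methoxy group instead, and in this assay compound 2 gives 86 nM. The step of a 1.1-fold higher number from compound 1 to compound 2 (0.04 log units; within the scatter) is within the scatter, so the two compounds cannot be told apart. Within the data shown here, of the two numbers, the one for compound 2 is the higher, but the gap to compound 1 lies within the scatter.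

Compound 3 `O=C(NNc1nc2ccccc2nc1Cc1ccccc1)c1ccc(Br)cc1` has not been measured. The change from compound 2 to compound 3 is bromo in place of methoxy on an aromatic carbon. Among the measured compounds shown here, only one step bears on this place: a 1.1-fold higher number from compound 1 to compound 2 (0.04 log units; within the scatter) showed that adding a methoxy group there changed nothing beyond the scatter. Nothing is known about a bromo group at this place. The step of a 1.1-fold lower number from compound 2 to compound 3 (0.03 log units; within the scatter) is therefore expected to be of no size beyond the scatter. Compound 3 is estimated to give 80 nM, within a range from 30 nM to 220 nM.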

Compound 3, half-maximal inhibitory concentration: 74 nM
Compound 3: middle estimate off by 1.1-fold (0.03 log units), on the high side, and the stated range covers the measured number.
By their numbers in this assay, from the lowest: compounds 3, 1 and 2 (each within the scatter of the next).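

Bromo now joins methoxy as a second group at this place, para to a large group on the outer ring, and in this assay the swap gives a 1.2-fold lower number from compound 2 to compound 3 (0.07 log units; within the scatter). Set against plain hydrogen, bromo gives a 1.1-fold lower number from compound 1 to compound 3 (0.02 log units; within the scatter), so hydrogen, methoxy and bromo at this place cannot be told apart by this read-out, although methoxy counts one hydrogen-bond acceptor and bromo none. Nothing available here says why these three groups give numbers that cannot be separated.

From the compounds shown here alone, all three compounds therefore leave this place without a single step beyond the scatter, and it remains open whether a group of another kind, such as an amine, a carboxylic acid or a longer chain, would move the number beyond it. Also open is whether changes elsewhere on the shared core would behave in the same way, as the compounds shown differ only at this one place.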